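A Methylene Inserted Before the Methoxyphenyl Group

The source may report more compounds than this note shows. Statements on the series, on what has been measured and on what is new or still open speak of the compounds shown alone.

Compound 1 `C[C@H](Oc1cccc(Cl)c1Cl)C(=O)Nc1ccc2oc(-c3ccc(OC(F)(F)F)cc3)nc2c1` was tested in an assay on isolated protein for inhibition of GMP reductase 2 (Homo sapiens), read by spectrophotometry (on this read-out higher numbers stand for weaker inhibition and lower numbers for stronger inhibition), and gave only a limit, > 5000 nM. Compound 2 `COc1ccc(-c2nc3cc(NC(=O)[C@H](C)Oc4cccc(Cl)c4Cl)ccc3o2)cc1`, which carries methyl in place of trifluoromethyl on an oxygen on an aromatic ring, likewise reached only a limit in this assay, > 5000 nM. Among the compounds with values here, the single measured step, a step that the two limits leave unreadable from compound 1 to compound 2, therefore cannot be read in size or direction. Within the data shown here, compound 2 thus stands at the limit of this assay, and the only evidence available is the limit of > 5000 nM in this assay, at which 2 of the 2 values shown sit, which is where compound 2 sits.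

Compound 3 `COc1ccc(Cc2nc3cc(NC(=O)[C@H](C)Oc4cccc(Cl)c4Cl)ccc3o2)cc1` differs from compound 2 by 4-methoxybenzyl in place of 4-methoxyphenyl on an aromatic carbon. Among the measured compounds shown here, no measured step bears directly on this change, and the one step that exists, between two compounds that both sit at the limit, gives no guide to what a change of this kind does. On the numbers shown, compound 3 is expected to remain at or beyond the limit of this assay, so the step that the limit leaves unreadable from compound 2 to compound 3 is expected to be small or not readable. The estimate for compound 3 in this assay is 10000 nM, within a range from 3000 nM to 50000 nM.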

Compound 3, inhibition constant: > 5000 nM
Compound 3 was reported as a limit; the forecaster's own chance of this, stated with the estimate: 80%; the middle value lies beyond the limit too.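

In this assay, within the data shown here, compound 3 gave > 5000 nM, which is a limit and not a number, so no step among compound 1, compound 2 and compound 3 can be read in size or direction. The compounds shown leave open what any of these changes does to inhibition, and all stand at one limit: the limit of > 5000 nM in this assay, at which 3 of the 3 values shown sit.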